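A few compounds are considered here, and "the series" means these few. Any claim that something is new, unique, unknown or untested is made for them only; others in the source may bear on it.

Measured compounds:
compound 1, `Cc1ccc(/C=C2\CCC/C(=C\c3cccc([N+](=O)[O-])c3)C2=O)cc1`, 38000 nM;
compound 2, `COc1ccc(/C=C2\CCC/C(=C\c3cccc([N+](=O)[O-])c3)C2=O)cc1`, 7200 nM;
compound 3, `Cc1ccc(/C=C2\CCC/C(=C\c3ccc([N+](=O)[O-])cc3)C2=O)cc1`, 27000 nM.

These three compounds were tested in a functional assay on HL-60 cells (Homo sapiens) for cytotoxicity, with a stated time of 24 h; a higher number here means that more compound is tolerated, a lower number that less compound is tolerated. Compound 1 and compound 2 share one core and differ by methoxy in place of methyl on an aromatic carbon; this change gave a 5.3-fold lower number from compound 1 to compound 2 (0.72 log units; beyond the scatter). Compound 3 carries a different core, and the difference between the two cores is not broken down here. In this assay compound 3 gives a number that sits close to that of compound 1, while compound 2 lies further off, below both.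

Compound 4, `COc1ccc(/C=C2\CCC/C(=C\c3ccc([N+](=O)[O-])cc3)C2=O)cc1`, has not yet been measured. It differs from compound 3 by methoxy in place of methyl on an aromatic carbon, which is the same change that separates compound 1 from compound 2, made on the other core. Because that change gave a 5.3-fold lower number from compound 1 to compound 2 (0.72 log units; beyond the scatter), the expected step from compound 3 to compound 4 is a 4.9-fold lower number from compound 3 to compound 4 (0.69 log units; beyond the scatter), resting on that single earlier pair alone. The estimate for compound 4 in this assay is therefore 5500 nM, expected to fall between 2500 nM and 12000 nM.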

Compound 4, half-maximal cytotoxic concentration: > 400000 nM
Compound 4 gave a limit, no number; the forecaster's own chance of this, stated with the estimate: 5%; at least 72-fold (1.86 log units) between middle value and limit.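

Methoxy in place of methyl on an aromatic carbon did not act alike on the two cores in this assay: the same change on two cores in this assay, a 5.3-fold lower number (0.72 log units; beyond the scatter) from compound 1 to compound 2 and an at least 14-fold higher number (1.17 log units; beyond the scatter) from compound 3 to compound 4, at least 78-fold (1.89 log units) apart, beyond the scatter of two such steps. On the core of compound 3 the change gave an at least 14-fold higher number from compound 3 to compound 4 (1.17 log units; beyond the scatter), opposite in direction to the step on the core of compound 1, so here the step on one core did not carry over to the other, although two pairs give no reason for the reversal and no rule for other cores. From the compounds shown here alone, compound 4 gave only a limit and not a number, so the full size of its step remains unknown: the limit of > 400000 nM in this assay, at which 1 of the 4 values shown sits.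

The compounds shown leave open whether the same reversal would appear with other groups in that place, such as an ethoxy group, a chlorine or an amine. They also leave open which part of the difference between the two cores goes with the reversal.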